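The source may hold more compounds than are shown below. What is called first, only, known or untested is meant among the compounds shown, and "the series" means these compounds.

Compound 1 `O=C(CSc1nc(Nc2ccccc2)c2ccccc2n1)Nc1cccc(F)c1` and compound 2 `C=CC(=O)Nc1cccc(NC(=O)CSc2nc(Nc3cccc(C)c3)c3ccccc3n2)c1` share a core in which a sulfur-linked acetamide carries an aromatic ring; both were tested in a functional assay on MDA-MB-231 cells (Homo sapiens) for inhibition, read by MTT assay, with a stated time of 72 h; a lower number here means a stronger inhibitor, a higher number a weaker inhibitor. Compound 1 gives > 50000 nM, a limit of the method rather than a measured number, namely (the limit of > 50000 nM in this assay, at which 1 of the 2 values shown sits). Among the measured compounds shown here, compound 2 is the one member of the pair that gives a number in this assay, at 16800 nM, so it stands as the only measured value and as the reference point for what follows. Compound 3 `C=CC(=O)Nc1cccc(NC(=O)CSc2nc(Nc3ccc(Cl)cc3Cl)c3ccccc3n2)c1` keeps everything in compound 2 except the ring on the nitrogen on the aromatic ring, where the change is 2,4-dichlorophenyl in place of 3-methylphenyl on a nitrogen on an aromatic ring. For the measured compounds named here, no measured step joins two compounds differing in only one place, so the size of this step can only be guessed. Compound 3 is expected to stay close to compound 2, with the step of a 1.2-fold lower number from compound 2 to compound 3 (0.08 log units; within the scatter) lying within the usual scatter. Compound 3 is estimated at 14000 nM in this assay, most likely between 4500 nM and 45000 nM.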

Compound 3, half-maximal inhibitory concentration: 23100 nM
For compound 3 the middle estimate is 1.7-fold (0.22 log units) below the measured one; the range from low to high includes it.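

In this assay, among the compounds shown here, the step of a 1.4-fold higher number from compound 2 to compound 3 (0.14 log units; within the scatter) is the first reading between two measured compounds that differ in one place, and it means that the two compounds cannot be told apart. On this nitrogen, 2,4-dichlorophenyl and 3-methylphenyl therefore give values that count as the same within the normal noise of the assay, even though one ring carries chlorine and the other a methyl group. Nothing shown accounts for the values of these compounds, and this single pair gives no ground for preferring either group.

From the compounds shown here alone, both groups are six-membered aromatic rings of carbon only, with no hydrogen-bond donors or acceptors and no net charge, so it remains open whether this position responds at all to a group of a different kind. A ring bearing a carboxylic acid or an amine, or a longer chain of carbon atoms in place of the ring, would test this more sharply than another swap between similar phenyl groups.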